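Swapping a hydroxyphenyl amide for a bromophenyl amide

The compounds below may be only part of what the source reports. "The series", "measured", "known", "first", "only" and "open" are said of these compounds alone.

In a functional assay on OVCAR-5 cells (Homo sapiens) for inhibition, read by CCK-8 assay, with a stated time of 72 h, tested at 10 uM (a lower number here means less inhibition of growth, a higher number more inhibition of growth at the concentration tested), compound 3 `CN(C)C(=O)c1cc2cnc(Nc3ccc(NC(=O)C4(C(=O)Nc5cccc(O)c5)CC4)cc3)nc2n1C1CCCC1` gives 86%, the highest of the three numbers shown. Compound 1 `CN(C)C(=O)c1cc2cnc(Nc3ccc(NC(=O)C4(C(=O)Nc5ccc(F)cc5)CC4)cc3)nc2n1C1CCCC1` gives 79.7%, within the scatter of compound 3, while compound 2 `CN(C)C(=O)c1cc2cnc(Nc3ccc(N)cn3)nc2n1C1CCCC1` gives 68%, a gap beyond the scatter. Compound 4 `CN(C)C(=O)c1cc2cnc(Nc3ccc(NC(=O)C4(C(=O)Nc5ccc(Br)cc5)CC4)cc3)nc2n1C1CCCC1` differs from compound 3 by 4-bromophenyl in place of 3-hydroxyphenyl on an amide-type nitrogen. Going by the values given here, the one step that bears on this place is a number 6.3 percentage points higher from compound 1 to compound 3 (within the scatter), where a 4-fluorophenyl was exchanged for the 3-hydroxyphenyl without a change beyond the scatter; the new 4-bromophenyl returns a halogen to the same place. No step beyond the scatter is therefore expected, and a number 5 percentage points lower from compound 3 to compound 4 (within the scatter) is estimated to be flat. Compound 4 is expected to give 81%, between 66% and 92%.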

Compound 4, percent growth inhibition at one concentration: 87.8%
Compound 4: middle estimate off by 6.8 percentage points, on the low side; the measured number falls inside the stated range.
By their numbers in this assay, from the lowest: compound 2; then compounds 1, 3 and 4 (each within the scatter of the next).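

In this assay, the step of a number 1.8 percentage points higher from compound 3 to compound 4 (within the scatter) shows that the position on the amide-type nitrogen tolerates 4-bromophenyl in place of 3-hydroxyphenyl, although the entering group has no hydrogen-bond donor or acceptor. The step of a number 8.1 percentage points higher from compound 1 to compound 4 (within the scatter), bromo in place of fluoro on an aromatic carbon, also stays within the scatter, so neither exchange separates these compounds here. Nothing shown accounts for this tolerance. On these data alone, whether an amine or a carboxylic acid on this phenyl ring, or a longer chain in its place, would keep this level of growth inhibition remains open.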